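The source may hold more compounds than are shown below. What is called first, only, known or untested is meant among the compounds shown, and "the series" means these compounds.

In a functional assay on CWR22R cells (Homo sapiens) for inhibition, read by MTT assay (on this read-out lower numbers stand for stronger inhibition of growth and higher numbers for weaker inhibition of growth), compound 1 `CC1=C(/C=C/C(C)=C/C=C/C(C)=C\C(=O)Nc2ccccc2)C(C)(C)CCC1n1ccnc1` gives 1280 nM and compound 2 `CC1=C(/C=C/C(C)=C/C=C/C(C)=C\C(=O)Nc2ccc(O)cc2)C(C)(C)CCC1n1ccnc1` gives 3890 nM as the higher of the two numbers, so it is the weaker growth inhibitor of this pair. Compound 3 `CC1=C(/C=C/C(C)=C/C=C/C(C)=C\C(=O)Nc2cccc(F)c2)C(C)(C)CCC1n1ccnc1` is still unmeasured and carries 3-fluorophenyl in place of 4-hydroxyphenyl on an amide-type nitrogen. For the measured compounds named here, only one measured step bears on this change: hydroxy in place of hydrogen on an aromatic carbon gave a 3.0-fold higher number from compound 1 to compound 2 (0.48 log units; beyond the scatter) as a modest loss. Going by the values given here, compound 3 lacks that hydroxy, as does compound 1 at 1280 nM and so a step back of similar size toward lower numbers is expected in this assay even though no measurement yet shows what the fluorine adds. The expected change is an estimated 3.2-fold lower number from compound 2 to compound 3 (0.51 log units; beyond the scatter) in this direction. The estimate for compound 3 is 1200 nM with an expected range from 500 nM to 3000 nM at its upper end.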

Compound 3, concentration for 50% growth inhibition: 2040 nM
Estimate against measurement, compound 3: 1.7-fold (0.23 log units) below; measured number inside the range.
By their numbers in this assay, from the lowest: compounds 1, 3 and 2 (each within the scatter of the next, the first and the last beyond it).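

In this assay, fluoro in place of hydrogen on the aromatic ring gives a 1.6-fold higher number from compound 1 to compound 3 (0.20 log units; within the scatter) and so adds a new kind of substituent that cannot be told apart from the unsubstituted phenyl. Replacing 4-hydroxyphenyl with 3-fluorophenyl on the amide-type nitrogen gives a 1.9-fold lower number from compound 2 to compound 3 (0.28 log units; within the scatter) so compound 3 cannot be placed apart from either neighbour, even though compound 1 and compound 2 differ beyond the scatter. No measured property is available to explain these numbers.

Each substituent is shown at only one place on the phenyl ring, so the effect of moving it remains open. As far as these compounds go, it also remains open how an amine, a methoxy group or a carboxylic acid on that ring would read in this assay.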